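A few compounds are considered here, and "the series" means these few. Any claim that something is new, unique, unknown or untested is made for them only; others in the source may bear on it.

Values in a functional assay on NCI-H460 cells (Homo sapiens) for inhibition, read by MTT assay, with a stated time of 24 h, tested at 100 ug/mL; on this read-out higher numbers stand for more inhibition of growth at the one concentration tested and lower numbers for less inhibition of growth:

compound 1 `O=C(CCCCC1CCSS1)Nc1cccc(C(F)(F)F)c1`: 68.8%
compound 2 `O=C(CCCCC(S)CCS)Nc1ccccc1`: 25.4%
compound 3 `O=C(CCCCC(S)CCS)Nc1cccc(Cl)c1`: 24.8%

Compound 3 at 24.8% and compound 2 at 25.4% lie within the scatter of each other, and compound 1 at 68.8% is well higher than both. Next in the series is compound 4 `O=C(CCCCC(S)CCS)Nc1cccc(C(F)(F)F)c1`, which keeps the core of compound 3 and has trifluoromethyl in place of chloro on an aromatic carbon. Within the data shown here, the one measured step at an aromatic carbon of this core, a number 0.6 percentage points lower from compound 2 to compound 3 (within the scatter), is small and concerns chloro in place of hydrogen. No trifluoromethyl has been measured on this core. Compound 1 at 68.8% carries trifluoromethyl on a different core, so it serves only as a reason to leave the upper end of the range wide. In this assay no step beyond the scatter is expected, with a slight rise at most. The expected step is a number 3.2 percentage points higher from compound 3 to compound 4 (within the scatter). For compound 4 the estimated value is 28%, with an expected range of 14% to 48%.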

Compound 4, percent growth inhibition at one concentration: 32.1%
Compound 4: middle estimate off by 4.1 percentage points, on the low side; the measured number falls inside the stated range.
By their numbers in this assay, from the lowest: compounds 3, 2 and 4 (each within the scatter of the next); then compound 1.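

In this assay, trifluoromethyl on the aromatic carbon of the shared core gives a number 7.3 percentage points higher from compound 3 to compound 4 (within the scatter) and a number 6.7 percentage points higher from compound 2 to compound 4 (within the scatter), so this position has now carried hydrogen, chloro and trifluoromethyl with no step beyond the scatter. With trifluoromethyl held constant, compound 1 and compound 4 isolate the change on the saturated chain carbon: the open group in place of the five-membered non-aromatic ring gives a number 36.7 percentage points lower from compound 1 to compound 4 (beyond the scatter), far larger than either step at the aromatic carbon. No measurement available here explains either outcome.

From the compounds shown here alone, whether the ring-to-open gap holds with hydrogen or chloro on the aromatic carbon remains open, as it rests on a single pair. Also open is whether an amine or a carboxylic acid at that aromatic carbon would stay within the scatter of these compounds.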